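Swapping the Nitro Group for a Nitrile

The source may report more compounds than this note shows. Statements on the series, on what has been measured and on what is new or still open speak of the compounds shown alone.

compound 1 `NC(=S)N1CCc2c(OCCCCCOc3ccc(Cl)cc3)cccc21`: > 50000 nM
compound 2 `O=C(NC(=S)N1CCc2c(OCCCCCOc3ccc(Cl)cc3)cccc21)c1ccc([N+](=O)[O-])cc1`: 13600 nM

In an ADME assay on Huh-7 cells (Homo sapiens) for cytotoxicity (a higher number here means that more compound is tolerated, a lower number that less compound is tolerated), compound 1 gives > 50000 nM, a limit of the assay rather than a number (the limit of > 50000 nM in this assay, at which 1 of the 2 values shown sits). Among the measured compounds shown here, compound 2 gives 13600 nM, the only firm number here, and the step of an at least 3.6-fold lower number from compound 1 to compound 2 (0.56 log units; beyond the scatter) shows that adding the acyl group cost tolerance. Compound 3 `N#Cc1cccc(C(=O)NC(=S)N2CCc3c(OCCCCCOc4ccc(Cl)cc4)cccc32)c1` carries 3-cyanophenyl in place of 4-nitrophenyl on a carbonyl carbon. For the measured compounds named here, the one measured step touches a different part of the molecule, so it gives little guidance; a change within the scatter is expected, a 1.1-fold higher number from compound 2 to compound 3 (0.04 log units; within the scatter). Compound 3 is estimated at 15000 nM, between 6000 nM and 40000 nM.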

Compound 3, half-maximal cytotoxic concentration: 9750 nM
Estimate against measurement, compound 3: 1.5-fold (0.19 log units) above; the measured number falls inside the stated range.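

Putting 3-cyanophenyl in place of 4-nitrophenyl on the carbonyl carbon gives a 1.4-fold lower number from compound 2 to compound 3 (0.14 log units; within the scatter) in this assay, so this assay does not separate these two groups at this position. A second aryl carbonyl group on the amide-type nitrogen also lowers tolerance, with an at least 5.1-fold lower number from compound 1 to compound 3 (0.70 log units; beyond the scatter). Compound 1 gives a limit, not a number: the limit of > 50000 nM in this assay, at which 1 of the 3 values shown sits.

Still open, as far as these compounds go, is how a plain phenyl or a methyl group on this carbonyl carbon would fare. Also open, from the compounds shown here alone, is whether 4-cyanophenyl would read like 3-cyanophenyl.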